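The source may hold more compounds than are shown below. What is called first, only, known or untested is meant among the compounds shown, and "the series" means these compounds.

Compound 3 `Fc1cccc(COc2ccc(-c3cc(CN4CCN(Cc5ccc(C(F)(F)F)cc5)CC4)no3)cc2)c1` gives the highest number of the three measured compounds in a functional assay on Huh-7 cells (Homo sapiens) for antiproliferative activity, read by sulforhodamine B assay, with a stated time of 72 h (a lower number here means a stronger inhibitor, a higher number a weaker inhibitor), at 1300 nM. Its nearest neighbour is compound 1 `FC(F)(F)c1ccc(CN2CCN(Cc3cc(-c4ccc(OCc5ccccc5Cl)cc4)on3)CC2)cc1`, which gives 1000 nM in this assay, a gap printed as a 1.3-fold higher number from compound 1 to compound 3 (0.11 log units; within the scatter). Further away is compound 2 `FC(F)(F)c1ccc(CN2CCN(Cc3cc(-c4ccc(OCc5cccc(Cl)c5)cc4)on3)CC2)cc1`, which gives 200 nM; the step from it to compound 3 is a 6.5-fold higher number from compound 2 to compound 3 (0.81 log units; beyond the scatter), while the step between the two chlorophenyl compounds was a 5.0-fold lower number from compound 1 to compound 2 (0.70 log units; beyond the scatter). Compound 4 `COc1cc(COc2ccc(-c3cc(CN4CCN(Cc5ccc(C(F)(F)F)cc5)CC4)no3)cc2)cc(OC)c1OC` carries the change (3,4,5-trimethoxyphenyl in place of 3-fluorophenyl on a saturated chain carbon bound to an oxygen on an aromatic ring). Both measured steps that touch the same place, a 1.3-fold higher number from compound 1 to compound 3 (0.11 log units; within the scatter) and a 6.5-fold higher number from compound 2 to compound 3 (0.81 log units; beyond the scatter), stay within a modest range, and none of them puts a 3,4,5-trimethoxyphenyl there, so the present data give no direct guide to the size of the new step. On that basis a step of no more than modest size, in either direction, is expected, with a slight lean toward a lower number, estimated as a 1.6-fold lower number from compound 3 to compound 4 (0.21 log units; within the scatter). Compound 4 is therefore expected to give about 800 nM in this assay, within a range from 200 nM to 3500 nM.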

Compound 4, half-maximal inhibitory concentration: 500 nM
The estimate for compound 4 lay 1.6-fold (0.20 log units) above the measured number, within the range that was stated.
By their numbers in this assay, from the lowest: compound 2; then compounds 4, 1 and 3 (each within the scatter of the next, the first and the last beyond it).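

Among these compounds, at this place, on a saturated chain carbon bound to an oxygen on an aromatic ring, the earlier compounds carried only halogenated phenyl groups, and 3,4,5-trimethoxyphenyl now shows that a group of 12 heavy atoms still gives a measurable number in this assay with a 2.6-fold lower number from compound 3 to compound 4 (0.41 log units; beyond the scatter) against the 3-fluorophenyl group. The 3-chlorophenyl group keeps the lowest number, as seen in a 2.5-fold higher number from compound 2 to compound 4 (0.40 log units; beyond the scatter) while the comparison with 2-chlorophenyl, a 2.0-fold lower number from compound 1 to compound 4 (0.30 log units; within the scatter) lies within the scatter, so the new group falls inside the span the halogenated groups had already set. Nothing in the material at hand explains these differences.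

Among the compounds shown here, whether all three methoxy groups are needed stays open, since no compound here carries a phenyl with a single methoxy group. Going by these compounds, how an unsubstituted phenyl, or a phenyl bearing an amine or a carboxylic acid, would compare at this place also remains unknown.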